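This account rests on a few compounds, and the source may have more. Where it says the series, first, only, none or still open, it means among the compounds named here.

Measured compounds in an assay on HEK293 cells for displacement of a labelled ligand from Melanocortin receptor 4 (Homo sapiens); on this read-out lower numbers stand for stronger inhibition and higher numbers for weaker inhibition:
- compound 1, `CC(C)C[C@H](N)c1cc(C(F)(F)F)ccc1N1CCN(C(=O)CCc2ccccc2Cl)CC1`: 1700 nM
- compound 2, `CC(C)C[C@H](N)c1cc(C(F)(F)F)ccc1N1CCN(C(=O)CCc2cccc(C(F)(F)F)c2)CC1`: 2200 nM
- compound 3, `COc1cccc(CCC(=O)N2CCN(c3ccc(C(F)(F)F)cc3[C@@H](N)CC(C)C)CC2)c1`: 4000 nM

Compound 3 gives the highest of the three numbers. Its nearest neighbour is compound 2, a step of a 1.8-fold higher number from compound 2 to compound 3 (0.26 log units; within the scatter), which stays within the scatter; the step from compound 1 is larger, a 2.4-fold higher number from compound 1 to compound 3 (0.37 log units; beyond the scatter), and lies beyond it.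

Compound 4, `COc1ccc(CCC(=O)N2CCN(c3ccc(C(F)(F)F)cc3[C@@H](N)CC(C)C)CC2)cc1`, is not yet measured. It differs from compound 3 in one place: 4-methoxyphenyl in place of 3-methoxyphenyl on a saturated chain carbon, two bonds along the chain from a carbonyl carbon. Within the data shown here, no measured step varies the aryl group in exactly this way. Among the measured compounds shown here, the steps that bear on it are those that exchange the aryl on the same chain carbon: a 1.3-fold higher number from compound 1 to compound 2 (0.11 log units; within the scatter) and a 2.4-fold higher number from compound 1 to compound 3 (0.37 log units; beyond the scatter), and the exchange of a substituent on that ring, a 1.8-fold higher number from compound 2 to compound 3 (0.26 log units; within the scatter). All three stay small, two within the scatter and one only modestly beyond. The change from compound 3 to compound 4 keeps the same atoms and moves one substituent on the ring, so no step beyond the scatter is expected in this assay in either direction.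

Compound 4 is therefore estimated at 3500 nM, with a range from 1500 nM to 8000 nM; the expected step is a 1.1-fold lower number from compound 3 to compound 4 (0.06 log units; within the scatter).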

Compound 4, inhibition constant: 350 nM
For compound 4 the middle estimate is 10-fold (1.00 log units) above the measured one; measured number below the stated range.
By their numbers in this assay, from the lowest: compound 4; then compounds 1, 2 and 3 (each within the scatter of the next, the first and the last beyond it).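

In this assay, 4-methoxyphenyl in place of 3-methoxyphenyl gives an 11-fold lower number from compound 3 to compound 4 (1.06 log units; beyond the scatter), so with the same atoms, the place of the methoxy group on the ring matters more at this chain carbon than the earlier aryl exchanges suggested, the largest of which was a 2.4-fold higher number from compound 1 to compound 3 (0.37 log units; beyond the scatter). The 4-methoxyphenyl group also stands apart from the other two aryl groups, with a 6.3-fold lower number from compound 2 to compound 4 (0.80 log units; beyond the scatter) and a 4.9-fold lower number from compound 1 to compound 4 (0.69 log units; beyond the scatter), which makes compound 4 the only one of the series whose steps to all the others lie beyond the scatter. The data shown offer nothing that accounts for this difference between the two methoxyphenyl isomers.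

Going by these compounds, it remains open whether the lower number goes with the methoxy group itself or with other groups in the same ring place, as 4-ethoxyphenyl, 4-chlorophenyl or 4-hydroxyphenyl would show, and how 2-methoxyphenyl would compare with the two isomers in hand. Also open, on these data alone, is whether the effect of the 4-methoxyphenyl group holds on a longer chain between the ring and the carbonyl.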